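Adding a second methoxy on the pendant aryl of compound 2

The compounds below may be only part of what the source reports. "The series", "measured", "known", "first", "only" and "open" are said of these compounds alone.

In a functional assay on aorta (strain Wistar) for inhibition, with Thoracic aorta (Rattus norvegicus) as the target (a higher number here means a weaker inhibitor, a lower number a stronger inhibitor), compound 1 `COc1nc(-c2cc3ccccc3o2)cc(-c2ccc(Cl)cc2Cl)c1C#N` gives 322000 nM and compound 2 `COc1ccc(-c2cc(-c3cc4ccccc4o3)nc(OC)c2C#N)cc1` gives 262000 nM. Compound 2 holds the lower of the two numbers shown, but a 1.2-fold lower number from compound 1 to compound 2 (0.09 log units; within the scatter) leaves both within the scatter. Compound 3 `COc1ccc(-c2cc(-c3cc4ccccc4o3)nc(OC)c2C#N)c(OC)c1` differs from compound 2 by methoxy in place of hydrogen on an aromatic carbon. Going by the values given here, the only measured step swaps the whole aryl group, so it does not bear directly on adding a methoxy, and no step shows how an extra methoxy acts. The expectation is therefore no change beyond the scatter, with a 1.0-fold lower number from compound 2 to compound 3 (0.02 log units; within the scatter) estimated. For compound 3 in this assay, 250000 nM is estimated, with a range of 100000 nM to 600000 nM.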

Compound 3, half-maximal inhibitory concentration: 425000 nM
Estimate against measurement, compound 3: 1.7-fold (0.23 log units) below; measured number inside the range.
By their numbers in this assay, from the lowest: compounds 2, 1 and 3 (each within the scatter of the next).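

In this assay, methoxy in place of hydrogen on an aromatic carbon, ortho to a large group and meta to a methoxy group, gives a 1.6-fold higher number from compound 2 to compound 3 (0.21 log units; within the scatter). Going by these compounds alone, this is the first step that adds a group to the pendant aryl instead of swapping the whole aryl, and it stays within the scatter. No measured evidence available here bears on this result.

From the compounds shown here alone, whether an amine or a carboxylic acid at this position would give a step beyond the scatter remains open. The same holds for a longer chain in place of the methoxy.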